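The source may hold more compounds than are shown below. What is called first, only, known or untested is meant among the compounds shown, and "the series" means these compounds.

Series notes, metabolic stability. Compound 1 `CCn1c(-c2cnc(C)nc2)nc2c(O[C@H]3CCN(C(=O)C4CC4)C3)ncnc21` is read in an ADME assay (Canis lupus familiaris, strain Beagle) for metabolic stability (on this read-out lower numbers stand for a shorter-lived compound and higher numbers for a longer-lived compound), where compound 1 gives 1.3 h. Compound 2 `CCn1c(-c2cnc(C)nc2)nc2c(N[C@H]3CCN(C(=O)C4CCC4)C3)ncnc21`, which carries an amide-type nitrogen link to the core in place of the ether link, gives 1.3 h in this assay, level with compound 1 at the digits shown and within the scatter. Compound 3 `CCn1c(-c2ccc(C(F)(F)F)nc2)nc2c(O[C@H]3CCN(C(=O)[C@H]4C[C@@H](OC)C4)C3)ncnc21`, with a trifluoromethyl-bearing pyridine on the core and a methoxy-bearing cyclobutane on the carbonyl, gives 2.6 h in this assay; its gap to compound 1 stays within the usual scatter, so no ordering among the three is claimed.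

The step considered runs from compound 1 to compound 4 `CCn1c(-c2cnc(C)nc2)nc2c(O[C@H]3CCN(C(=O)C4CCOC4)C3)ncnc21`, not yet measured in this assay. The change is oxolan-3-yl in place of cyclopropyl on a carbonyl carbon whose other neighbours are an amide-type nitrogen in a ring. Among the measured compounds shown here, no measured pair in the set shows this or any single change, so the size of the step is not known from data. For compound 4 the step of no change at the digits printed from compound 1 to compound 4 (within the scatter) is expected to stay within the scatter, with no direction beyond it. Compound 4 is therefore estimated at 1.3 h, within 0.7 h to 2.6 h.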

Compound 4, half-life: 3.8 h
Compound 4: the middle estimate sits 2.9-fold (0.47 log units) below what was measured, and the stated range ends below it.
By their numbers in this assay, from the lowest: compounds 1, 2, 3 and 4 (each within the scatter of the next, the first and the last beyond it).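

In this assay, among the compounds shown here, the step of a 2.9-fold higher number from compound 1 to compound 4 (0.47 log units; beyond the scatter) is the first single-place comparison, and it shows that the group on a carbonyl carbon whose other neighbours are an amide-type nitrogen in a ring can move this read-out beyond the scatter. The earlier compounds shown here could not show this, since compounds 1, 2 and 3 each differ from one another in more than one place. Nothing at hand explains the step.

The change alters ring size and adds a ring oxygen at once, so a cyclopentyl or oxetan-3-yl group on the same carbonyl would be needed to separate the two. Going by these compounds, whether the step carries over to the nitrogen-linked compound 2 or to the trifluoromethyl-bearing compound 3 also remains open.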